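A Crown Ether Ester Series and a Pyridine Variant

The source may report more compounds than this note shows. Statements on the series, on what has been measured and on what is new or still open speak of the compounds shown alone.

Compound 1 `O=C(CCCCC1CCCCC1)OCC1COCCOCCOCCOCCOCCO1`: 51000 nM
Compound 2 `CC(C)=CC1C(C(=O)OCC2COCCOCCOCCOCCOCCO2)C1(C)C`: 54000 nM
Compound 3 `O=C(OCC1COCCOCCOCCOCCOCCO1)c1cccc(-c2ccc(Br)cc2)c1`: 4400 nM

In a functional assay on SW1573 cells (Homo sapiens) for inhibition, read by sulforhodamine B assay, with a stated time of 48 h (on this read-out lower numbers stand for stronger inhibition of growth and higher numbers for weaker inhibition of growth), compound 1 gives 51000 nM, the second highest of the three numbers. Its nearest neighbour is compound 2, and a 1.1-fold higher number from compound 1 to compound 2 (0.02 log units; within the scatter), a change within the scatter. Among the compounds with values here, compound 3, with an aromatic group on the carbonyl carbon, gives 4400 nM, a lower number than compound 1, but no single-change step joins the two. Compound 4 `O=C(OCC1COCCOCCOCCOCCOCCO1)c1cccnc1` differs from compound 1 by pyridin-3-yl in place of 4-cyclohexylbutyl on a carbonyl carbon. Within the data shown here, the only measured step from compound 1 swapped one non-aromatic group for another and stayed within the scatter, so no measured step shows an aromatic group entering at this position. Compound 4 is therefore expected to give 35000 nM, within 9000 nM to 120000 nM, an expected 1.5-fold lower number from compound 1 to compound 4 (0.16 log units; within the scatter).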

Compound 4, concentration for 50% growth inhibition: > 100000 nM
Compound 4 gave a limit, no number (the forecaster's own chance of this, stated with the estimate: 20%); middle value at least 2.8-fold (0.45 log units) from the limit.
By their numbers in this assay, from the lowest: compound 3; then compounds 1 and 2 (each within the scatter of the next). At a limit, above all of these: compound 4.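

Compound 4 stands at a limit, not at a number: the limit of > 100000 nM in this assay, at which 1 of the 4 values shown sits. In this assay pyridin-3-yl on the carbonyl carbon gives an at least 1.9-fold higher number from compound 1 to compound 4 (0.29 log units; that floor lies within the scatter) and also an at least 1.8-fold higher number from compound 2 to compound 4 (0.26 log units; that floor lies within the scatter) as the second step. Both floors lie within the scatter, so this first step that brings an aromatic ring to this position shows no lower number, and the true size of the rise cannot be read. On these data alone, whether a plain phenyl ring at this position would give a lower number stays open. So does the effect of an amine or a carboxylic acid on the pyridine ring.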